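Dropping One Trifluoromethyl from a Bis-Substituted Urea

The compounds below may be only part of what the source reports. "The series", "measured", "known", "first", "only" and "open" are said of these compounds alone.

Three ureas built on a shared core have been tested in a functional assay on PC-3 cells (Homo sapiens) for inhibition, read by sulforhodamine B assay, with a stated time of 48 h, tested at 100 uM; a higher number here means a weaker effect of the compound at the concentration tested, a lower number a stronger effect. Compound 1 `O=C(Nc1cccc(-n2cc(-c3ccncc3)c(-c3cc(O)cc(Cl)c3)n2)c1)Nc1ccc(Cl)c(C(F)(F)F)c1` gives -83% in this assay. Compound 2 `O=C(Nc1cccc(-n2cc(-c3ccncc3)c(-c3cc(O)cc(Cl)c3)n2)c1)Nc1ccc(Cl)c(Cl)c1` gives -35% in this assay, and compound 3 `COc1cc(Cl)cc(-c2nn(-c3cccc(NC(=O)Nc4cc(C(F)(F)F)cc(C(F)(F)F)c4)c3)cc2-c2ccncc2)c1` gives -44% there. Among these three numbers compound 3 stands second highest: its nearest neighbour is compound 2, whose value sits within the scatter of it, while compound 1 lies well below it, beyond the scatter. For the measured compounds named here, the one measured step that swaps a single group, chloro in place of trifluoromethyl on an aromatic carbon, moved the number a number 48 percentage points higher from compound 1 to compound 2 (beyond the scatter), a large shift toward weaker effect.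

Compound 4 `COc1cc(Cl)cc(-c2nn(-c3cccc(NC(=O)Nc4cccc(C(F)(F)F)c4)c3)cc2-c2ccncc2)c1` differs from compound 3 in one place: hydrogen in place of trifluoromethyl on an aromatic carbon, at a position meta to a trifluoromethyl group. Going by the values given here, the only measured step that bears on it is that loss of a trifluoromethyl from compound 1 to compound 2, which weakened the effect substantially. Among the compounds with values here, removing a trifluoromethyl in compound 4 is therefore expected to raise the number as well, though with only one comparable step the size is uncertain; the expected step is a number 29 percentage points higher from compound 3 to compound 4 (beyond the scatter). Compound 4 is accordingly estimated at -15%, with a range from -60% to 20%.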

Compound 4, a percentage reported as activity, at one concentration (the size of the read-out at that concentration, not a potency): -35%
Estimate against measurement, compound 4: 20 percentage points above; measured number inside the range.
By their numbers in this assay, from the lowest: compound 1; then compounds 3, 2 and 4 (each within the scatter of the next).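

At this position, meta to a trifluoromethyl group, trading trifluoromethyl for hydrogen in this assay gives a number 9 percentage points higher from compound 3 to compound 4 (within the scatter), so on this core the second trifluoromethyl is not needed to keep the read-out within the scatter of that of compound 3. For the compounds shown here, this sets the hydrogen swap apart from the only earlier single-group step, chloro in place of trifluoromethyl, which gave a number 48 percentage points higher from compound 1 to compound 2 (beyond the scatter) and so showed that losing a trifluoromethyl can matter greatly; the two steps differ in the entering group, the position and the rest of the molecule, so they show only that such a loss does not act alike in every setting. Nothing measured here accounts for this difference between the two steps.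

The compounds shown leave open whether hydrogen in place of trifluoromethyl would read the same way on the core of compound 1, which carries a hydroxyl where compound 3 carries a methoxy. They also leave open how an amine or a carboxylic acid at this position would stand in this assay against hydrogen and trifluoromethyl.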